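Series notes: removing the 3-methoxyphenyl group

This account rests on a few compounds, and the source may have more. Where it says the series, first, only, none or still open, it means among the compounds named here.

compound 1 `COc1ccc(N2C(=O)COc3ccc(-c4ccc(O)cc4)cc32)cc1`: 26100 nM
compound 2 `COc1cccc(N2C(=O)COc3ccc(-c4ccc(O)cc4)cc32)c1`: 15300 nM

In a functional assay on HCT-116 cells (Homo sapiens) for antiproliferative activity, read by MTT assay, with a stated time of 72 h (a lower number here means a stronger inhibitor, a higher number a weaker inhibitor), compound 2 gives 15300 nM and does not stand apart from compound 1. Within the data shown here, the only measured step, a 1.7-fold lower number from compound 1 to compound 2 (0.23 log units; within the scatter), is within the scatter.

The next compound, compound 3 `O=C1COc2ccc(-c3ccc(O)cc3)cc2N1`, is unmeasured. Its change from compound 2 is hydrogen in place of 3-methoxyphenyl on an amide-type nitrogen in a ring. The measured step bears on this only loosely, since it exchanged one methoxyphenyl group for another and kept a group on that nitrogen. Among the measured compounds shown here, no measured compound has lost the group altogether, so the data give no direct size or direction for this change. A modest step towards a higher number in this assay is expected, although a result within the scatter would be no surprise. The estimated step is a 2.1-fold higher number from compound 2 to compound 3 (0.32 log units; beyond the scatter). For compound 3 the expected value is 32000 nM, with an estimated range of 10000 nM to 100000 nM.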

Compound 3, half-maximal inhibitory concentration: > 40000 nM
Compound 3: no number, only a limit (the forecaster's own chance of this, stated with the estimate: 20%); at least 1.2-fold (0.09 log units) between middle value and limit.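

In this assay compound 3 gives > 40000 nM, which is a limit of the assay and not a number. Hydrogen in place of 3-methoxyphenyl on the amide-type nitrogen gives an at least 2.6-fold higher number from compound 2 to compound 3 (0.41 log units; beyond the scatter), so this position, where exchanging one methoxyphenyl group for the other produced no step beyond the scatter, does respond when the group is removed altogether. Against the 4-methoxyphenyl group the same removal gives an at least 1.5-fold higher number from compound 1 to compound 3 (0.18 log units; that floor lies within the scatter), so the limit alone does not separate compound 3 from compound 1, and the response at this position is established only against compound 2.

On these data alone, how far the true value of compound 3 lies past its limit stays open, and with it the full size of both steps: the limit of > 40000 nM in this assay, at which 1 of the 3 values shown sits. Also open is whether a methyl group, or a short chain ending in an amine, on this nitrogen would give a number close to that of compound 2 or one that also reaches the limit seen for compound 3.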